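Halogen exchange on the phenyl of the ether arm

The compounds below may be only part of what the source reports. "The series", "measured", "known", "first", "only" and "open" are said of these compounds alone.

Compound 3 `O=C(Nc1cccnc1)c1ccccc1OCc1cc(Cl)ccc1Cl` stands at 990 nM in an assay on lysate for inhibition of phosphatidylcholine:ceramide cholinephosphotransferase 2 (Homo sapiens), read by HPLC, with stated times of 30 min and 2 h; on this read-out lower numbers stand for stronger inhibition and higher numbers for weaker inhibition. Compound 2 `O=C(Nc1cccnc1)c1ccccc1OCc1cccc(Cl)c1` gives 1400 nM, and the gap between the two, a 1.4-fold lower number from compound 2 to compound 3 (0.15 log units; within the scatter), falls within the scatter, so the pair cannot be ranked against each other. Compound 1 `O=C(Nc1cccnc1)c1ccccc1OCc1ccccc1` gives 3200 nM; the step of a 3.2-fold lower number from compound 1 to compound 3 (0.51 log units; beyond the scatter) lies beyond the scatter, as does a 2.3-fold lower number from compound 1 to compound 2 (0.36 log units; beyond the scatter).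

Compound 4 `O=C(Nc1cccnc1)c1ccccc1OCc1cccc(Cl)c1F` differs from compound 3 by 3-chloro-2-fluorophenyl in place of 2,5-dichlorophenyl on a saturated chain carbon bound to an oxygen on an aromatic ring. One chloro stays on the ring; the second chloro gives way to a fluoro. The measured steps that bear on this are the two halogen additions on the phenyl on the saturated chain carbon bound to an oxygen on an aromatic ring: the first chloro, a 2.3-fold lower number from compound 1 to compound 2 (0.36 log units; beyond the scatter), is a modest step beyond the scatter, while the second, a 1.4-fold lower number from compound 2 to compound 3 (0.15 log units; within the scatter), stays within it. Nothing in the series shows what a fluoro on that ring does. Since one chloro is kept and the second contributed little in a 1.4-fold lower number from compound 2 to compound 3 (0.15 log units; within the scatter), the number for compound 4 is expected to land near those of compound 2 and compound 3, and the step of a 1.4-fold higher number from compound 3 to compound 4 (0.15 log units; within the scatter) is expected to remain within the scatter. The estimate for compound 4 is therefore 1400 nM, with a range from 600 nM to 3200 nM.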

Compound 4, half-maximal inhibitory concentration: 3100 nM
Beside the measured number, compound 4's estimate is 2.2-fold (0.35 log units) below it; measured number inside the range.
By their numbers in this assay, from the lowest: compounds 3 and 2 (each within the scatter of the next); then compounds 4 and 1 (each within the scatter of the next).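

On the phenyl on the saturated chain carbon bound to an oxygen on an aromatic ring, the kind of halogen now counts: in this assay the exchange gives a 3.1-fold higher number from compound 3 to compound 4 (0.50 log units; beyond the scatter), and the fluoro in place of hydrogen on compound 2 gives a 2.2-fold higher number from compound 2 to compound 4 (0.35 log units; beyond the scatter), so compound 4 goes against the lower numbers that came with chloro on compounds 2 and 3. The gain from the chloro does not survive alongside this fluoro, since the step to the plain phenyl is only a 1.0-fold lower number from compound 1 to compound 4 (0.01 log units; within the scatter) and the two compounds cannot be separated in this read-out. No measurement in hand accounts for this reversal.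

The compounds shown leave open whether the fluoro raises the number on any phenyl here or only in combination with this chloro, a question that a phenyl carrying the fluoro alone would address. Going by these compounds, it also remains open how a bromo, a methyl or a methoxy would behave on the same ring, and so whether the effect is peculiar to fluoro or extends to other groups in its place.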